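Chloro to trifluoromethyl: a step still to be measured

The compounds below may be only part of what the source reports. "The series", "measured", "known", "first", "only" and "open" are said of these compounds alone.

Values measured in a functional assay on HL-60 cells (Homo sapiens) for cytotoxicity, read by CCK-8 assay, with a stated time of 24 h; a higher number here means a weaker inhibitor, a lower number a stronger inhibitor:
compound 1 `C=CC(=O)N1C(=O)CCSc2ccccc21`: 44800 nM
compound 2 `C=CC(=O)N1C(=O)CC(c2ccccc2Cl)Sc2ccccc21`: 91400 nM
compound 3 `C=CC(=O)N1C(=O)CC(c2cccs2)Sc2ccccc21`: 695000 nM

Compound 2 stands in the middle of these three numbers. Placing 2-chlorophenyl on a saturated ring carbon in place of hydrogen gives a 2.0-fold higher number from compound 1 to compound 2 (0.31 log units; beyond the scatter). Placing thiophen-2-yl there instead gives a 16-fold higher number from compound 1 to compound 3 (1.19 log units; beyond the scatter). Thiophen-2-yl in place of 2-chlorophenyl gives a 7.6-fold higher number from compound 2 to compound 3 (0.88 log units; beyond the scatter).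

Compound 4 `C=CC(=O)N1C(=O)CC(c2ccccc2C(F)(F)F)Sc2ccccc21` is still unmeasured and departs from compound 2 in one place: trifluoromethyl in place of chloro on an aromatic carbon. In words, it carries trifluoromethyl in place of chloro on an aromatic carbon. Among the compounds with values here, no measured step changes only a group on this aromatic ring, so the data offer no direct precedent. The three steps above all alter the whole group on the saturated ring carbon, and the largest of them removes the six-membered aromatic ring, which compound 4 keeps. A step of that size is therefore not expected in this assay, and the expectation is for little or no change beyond the scatter, with a slight lean towards a higher number. The expected step is a 1.3-fold higher number from compound 2 to compound 4 (0.12 log units; within the scatter). For compound 4 the estimated value is 120000 nM, with an expected range from 40000 nM to 400000 nM.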

Compound 4, half-maximal inhibitory concentration: 96400 nM
Compound 4: the middle estimate sits 1.2-fold (0.10 log units) above what was measured; the measured number falls inside the stated range.
By their numbers in this assay, from the lowest: compound 1; then compounds 2 and 4 (each within the scatter of the next); then compound 3.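

In this assay, trifluoromethyl in place of chloro gives a 1.1-fold higher number from compound 2 to compound 4 (0.02 log units; within the scatter); this is the first step shown that changes only a group on the six-membered aromatic ring, and it stays within the scatter. The earlier steps shown here all replaced the whole group on the saturated ring carbon, and each lay beyond the scatter, so they could not show whether a smaller edit on the aromatic carbon, ortho to a large group, would register in this read-out. Compound 2 and compound 4 cannot be told apart here, so this exchange, unlike those earlier steps, leaves the number in place, and nothing available explains why the two groups read alike.

As far as these compounds go, the pair covers only these two groups at one place, so it remains open whether an amine or a carboxylic acid on the same aromatic carbon would leave the number equally unmoved. From the compounds shown here alone, it also remains open whether trifluoromethyl in place of chloro would read the same at another carbon of that ring, or whether a methoxy group on the thiophene of compound 3 would shift its number.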